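From compound 3 to compound 4: hydroxy on the carbonyl

The compounds below may be only part of what the source reports. "The series", "measured", "known", "first", "only" and "open" are said of these compounds alone.

In a functional assay on K562 cells (Homo sapiens) for inhibition, read by sulforhodamine B assay, with a stated time of 48 h (on this read-out lower numbers stand for stronger inhibition of growth and higher numbers for weaker inhibition of growth), compound 1 `O=C(NNC(=O)c1ccc2[nH]c(-c3ccc([N+](=O)[O-])o3)nc2c1)c1ccccc1` gives 15.6 ug/mL, compound 2 `COc1cccc(C(=O)NNC(=O)c2ccc3[nH]c(-c4ccc([N+](=O)[O-])o4)nc3c2)c1` gives 15.6 ug/mL and compound 3 `O=CNNC(=O)c1ccc2[nH]c(-c3ccc([N+](=O)[O-])o3)nc2c1` gives 31.3 ug/mL. Within the data shown here, compound 3 therefore sits with the other two inside the scatter, and the series so far shows no separation in this assay.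

The next compound is compound 4 `O=C(O)c1ccc2[nH]c(-c3ccc([N+](=O)[O-])o3)nc2c1`, which is reached from compound 3 by this change: hydroxy in place of (formylamino)amino on a carbonyl carbon. Hydroxy stands in place of (formylamino)amino on a carbonyl carbon whose other neighbour is an aromatic carbon.

Among the measured compounds shown here, two measured steps bear on this most closely: a 2.0-fold higher number from compound 1 to compound 3 (0.30 log units; within the scatter) and a 2.0-fold higher number from compound 2 to compound 3 (0.30 log units; within the scatter). Both alter a carbonyl carbon inside the group that compound 4 loses, and both stay within the scatter. The step of no change at the digits printed from compound 1 to compound 2 (within the scatter) also shows no separation, but it concerns only a methoxy on an aromatic carbon. None of the three removes the whole group, so the data only loosely constrain the new step, and they favour no direction. A step no larger than the scatter is expected, with wide uncertainty: the expected step is a 1.0-fold lower number from compound 3 to compound 4 (0.00 log units; within the scatter).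

For compound 4 the estimated value in this assay is 31 ug/mL, with an expected range of 12 ug/mL to 90 ug/mL.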

Compound 4, concentration for 50% growth inhibition: 250 ug/mL
Compound 4: middle estimate off by 8.1-fold (0.91 log units), on the low side; measured number above the stated range.
By their numbers in this assay, from the lowest: compounds 1, 2 and 3 (each within the scatter of the next); then compound 4.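

In this assay, among these compounds, hydroxy in place of (formylamino)amino on a carbonyl carbon whose other neighbour is an aromatic carbon gives an 8.0-fold higher number from compound 3 to compound 4 (0.90 log units; beyond the scatter), the first step to lie beyond the scatter. The earlier exchanges among phenyl, 3-methoxyphenyl and hydrogen on the carbonyl carbon inside the group all stayed within the scatter, so those changes within the group produced no separation, whereas replacing the whole group, read one bond further out as (formylamino)carbamoyl to carboxy, does. Nothing available offers an explanation for this step.

From the compounds shown here alone, this rests on one compound pair, so the step cannot yet be assigned to the departure of (formylamino)amino or to the entry of hydroxy, and how a primary amide, a methyl ester or a plain hydrazide on the same carbonyl carbon would read in this assay remains open. Also open, going by these compounds, is whether a longer alkyl chain on the carbonyl carbon inside the group would stay with compound 1, compound 2 and compound 3.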